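Fluoro in place of methyl: compound 1 to compound 3

The source may hold more compounds than are shown below. What is called first, only, known or untested is meant among the compounds shown, and "the series" means these compounds.

Measured compounds:
compound 1: `Cc1ccc(-c2nnc(Nc3ncccn3)o2)cc1`, < 20%
compound 2: `c1cnc(Nc2nnc(-c3cccc4ccccc34)o2)nc1`, 60%

In a functional assay, with a stated time of 30 min, tested at 20 uM (on this read-out lower numbers stand for less inhibition and higher numbers for more inhibition at the one concentration tested (going by the name of the read-out)), compound 1 gives < 20%, a limit of the assay and not a number; compound 1 therefore sits at the limit of < 20% in this assay, at which 1 of the 2 values shown sits. In this assay compound 2 gives 60%. Compound 3 is `Fc1ccc(-c2nnc(Nc3ncccn3)o2)cc1`, differing from compound 1 by fluoro in place of methyl on an aromatic carbon. Among the measured compounds shown here, no measured pair differs in one place, so the size of such a change is untested. In this assay the expected step that the limit leaves unreadable from compound 1 to compound 3 is small, not beyond the scatter. Compound 3 is thus expected at 15%, between 0% and 35%, and may again be reported only as a limit.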

Compound 3, a percentage reported as inhibition, at one concentration (the size of the read-out at that concentration, not a potency): 41.9%
The estimate for compound 3 lay 26.9 percentage points below the measured number; measured number above the stated range.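

In this assay, fluoro in place of methyl on an aromatic carbon, para to a large group, gives a number at least 21.9 percentage points higher from compound 1 to compound 3 (beyond the scatter). This position therefore responds to the exchange of a single heavy atom while the rest of compound 1 stays unchanged. The step gives only a lower bound on the size of the change, as the value for compound 1 is a limit of the assay and not a number: the limit of < 20% in this assay, at which 1 of the 3 values shown sits.

On these data alone, whether this response extends to other groups at this position, such as chloro, methoxy or an amine, remains open. Also open, as far as these compounds go, is how the reading at one concentration relates to potency.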